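Carbamate chain homologation and metabolic half-life

A few compounds are considered here, and "the series" means these few. Any claim that something is new, unique, unknown or untested is made for them only; others in the source may bear on it.

Two cores appear in this set. Compound 1, `CCCCCCCCCNC(=O)Oc1ccc(Cl)cc1C(=O)Nc1cccc(Cl)c1`, and compound 2, `CCCCCCCCCCNC(=O)Oc1ccc(Cl)cc1C(=O)Nc1cccc(Cl)c1`, share one core; compound 3, `CCNC(=O)Oc1ccc(Cl)cc1C(=O)Nc1ccc(Cl)cc1`, and the not yet measured compound 4, `CCCNC(=O)Oc1ccc(Cl)cc1C(=O)Nc1ccc(Cl)cc1`, share the other. How the core of compound 3 differs from the core of compound 1 is not broken down here.

In an ADME assay for metabolic stability, read by HPLC, at pH 7 (on this read-out higher numbers stand for a longer-lived compound and lower numbers for a shorter-lived compound), compound 1 gives 64 h. Compound 2 gives 64 h in this assay. The change between the two is methyl in place of hydrogen on a saturated chain carbon, nine bonds along the chain from an amide-type nitrogen, and the step it made is no change at the digits printed from compound 1 to compound 2 (within the scatter). Compound 3 gives 64 h in this assay, level with compounds 1 and 2 within the scatter.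

Compound 4 carries the same kind of change relative to compound 3: methyl in place of hydrogen on a saturated chain carbon, two bonds along the chain from an amide-type nitrogen. The place is not the same word for word: in compound 2 the methyl sits nine bonds along the chain from an amide-type nitrogen, in compound 4 two bonds along the chain from an amide-type nitrogen, so the setting around the change differs even though the change itself is of the same kind. With only one measured occurrence of this kind of change, on the other core, the expectation stays close to flat. The expected step is no change at the digits printed from compound 3 to compound 4 (within the scatter), resting on the fact that the same kind of change on the other core gave no change at the digits printed from compound 1 to compound 2 (within the scatter). Compound 4 is therefore expected to give 64 h in this assay, with a range from 32 h to 128 h.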

Compound 4, half-life: 64 h
Beside the measured number, compound 4's estimate shows no gap at the digits printed; low and high end bracket the measured number.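

In this assay, methyl in place of hydrogen on a saturated chain carbon, two bonds along the chain from an amide-type nitrogen, gives no change at the digits printed from compound 3 to compound 4 (within the scatter), the ethylamino to propylamino change on the second core. Read beside the step on the first core, where the same kind of change sits nine bonds along the chain from an amide-type nitrogen, the flat result carries over from one core to the other in this series: the same change on two cores in this assay, no change at the digits printed (within the scatter) from compound 1 to compound 2 and no change at the digits printed (within the scatter) from compound 3 to compound 4, 1.0-fold (0.00 log units) apart, within the scatter of two such steps This shows only that two occurrences, on two cores and at two places along the chain, agree in giving no visible step; with neither step moving, it does not show that a real shift would carry over between the cores, nor does it show that the change stays flat at other places along the chain or on a further core.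

The compounds shown leave open whether the flat reading holds when the chain ends in an amine or a carboxylic acid, or when a branched chain or a ring stands in place of the straight chain. They also leave open what replacing the carbamate link with a plain amide would do to the half-life on either core.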